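Aryl group swaps: from compound 3 to compound 4

A few compounds are considered here, and "the series" means these few. Any claim that something is new, unique, unknown or untested is made for them only; others in the source may bear on it.

In an ADME assay on HEK293 cells (Homo sapiens) for cytotoxicity (on this read-out lower numbers stand for stronger inhibition and higher numbers for weaker inhibition), compound 1 (`CCCCCCCCCCCCCCNC(=O)[C@H](CO)/N=C/c1ccccc1[N+](=O)[O-]`) gives 82600 nM while compound 2 (`CCCCCCCCCCCCCCNC(=O)[C@H](CO)/N=C/c1ccccc1O`) gives 80800 nM and compound 3 (`CCCCCCCCCCCCCCNC(=O)[C@H](CO)/N=C/c1ccc(Cl)cc1`) gives 77700 nM as its reading. Compound 3 therefore stands level with the other two, and all three lie within the scatter of one another.

Compound 4 (`CCCCCCCCCCCCCCNC(=O)[C@H](CO)/N=C/c1ccc(O)cc1`) differs from compound 3 as follows: hydroxy in place of chloro on an aromatic carbon.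

Within the data shown here, no measured pair exchanges chloro for hydroxy directly, so the evidence is indirect. The swap of nitro for hydroxy gives a 1.0-fold lower number from compound 1 to compound 2 (0.01 log units; within the scatter) and the swaps to 4-chlorophenyl give a 1.1-fold lower number from compound 1 to compound 3 (0.03 log units; within the scatter) and a 1.0-fold lower number from compound 2 to compound 3 (0.02 log units; within the scatter) in this small set. All three steps stay within the scatter, so no step beyond it is expected in this assay for this change, in either direction. On these data alone, three compounds are a thin basis, and a hydroxy group at this place remains untested.

The expected step is a 1.0-fold higher number from compound 3 to compound 4 (0.00 log units; within the scatter) on this estimate. For compound 4 the estimated value is 78000 nM (expected range 48000 nM to 125000 nM).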

Compound 4, half-maximal inhibitory concentration: 71700 nM
Estimate against measurement, compound 4: 1.1-fold (0.04 log units) above, and the stated range covers the measured number.
By their numbers in this assay, from the lowest: compounds 4, 3, 2 and 1 (each within the scatter of the next).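

Working notes on the aryl position: in this assay, the direct exchange of chloro for hydroxy on the aromatic carbon para to a large group now has a reading of its own (a 1.1-fold lower number from compound 3 to compound 4 (0.03 log units; within the scatter)), and bringing in one hydrogen-bond donor and one hydrogen-bond acceptor at this place does not take the step beyond the scatter. The two other steps to the 4-hydroxyphenyl compound, one from the 2-hydroxyphenyl compound (a 1.1-fold lower number from compound 2 to compound 4 (0.05 log units; within the scatter)) and one from the 2-nitrophenyl compound (a 1.2-fold lower number from compound 1 to compound 4 (0.06 log units; within the scatter)), also stay within the scatter, so all four aryl groups shown stand level in this assay, with no compound going against that. No measurement on these compounds offers an explanation for this flat set of readings.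

The compounds shown leave open whether an amine or a carboxylic acid on the aromatic ring would give a step beyond the scatter, since the four groups here span only nitro, hydroxy and chloro. Among these compounds, they also leave open whether a longer chain in place of the one all four compounds share would change the reading, and whether the aryl swaps would stay this flat with it.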